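The compounds below may be only part of what the source reports. "The series", "measured", "known", "first", "only" and "open" are said of these compounds alone.

Compound 2 `Oc1ccc(-c2cc(-c3ccccc3F)cc(-c3ccccc3O)n2)cc1` is tested in a functional assay on T47D cells (Homo sapiens) for inhibition; a lower number here means a stronger inhibitor, a higher number a weaker inhibitor. In this assay compound 2 reaches only the limit > 50000 nM, so no number is known for it. Compound 1 `Oc1cccc(-c2cc(-c3ccccc3F)cc(-c3ccccc3O)n2)c1` gives 24200 nM in this assay, and the change from it, namely an at least 2.0-fold higher number from compound 1 to compound 2 (0.31 log units; beyond the scatter), is beyond the scatter. Compound 3 `Oc1ccc(-c2cc(-c3cccc(C(F)(F)F)c3)cc(-c3ccccc3O)n2)cc1` also sits at the limit > 50000 nM. The step from compound 2 to compound 3 is therefore a step that the two limits leave unreadable from compound 2 to compound 3, a consequence of the limit of > 50000 nM in this assay, at which 2 of the 3 values shown sit. Compound 4 `Oc1ccc(-c2cc(-c3ccccc3OC(F)(F)F)cc(-c3ccccc3O)n2)cc1` differs from compound 2 by trifluoromethoxy in place of fluoro on an aromatic carbon. Among the measured compounds shown here, the one measured step starting from compound 2 ended at the limit and gives no size, so the expected step is a step that the limit leaves unreadable from compound 2 to compound 4, none beyond the scatter. Compound 4 is accordingly estimated at 60000 nM, within 20000 nM to 200000 nM.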

Compound 4, half-maximal inhibitory concentration: 2050 nM
Estimate against measurement, compound 4: 29-fold (1.47 log units) above, outside the stated range (below it).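

In this assay, the aromatic carbon ortho to a large group turns out to respond strongly to its substituent: trifluoromethoxy in place of fluoro gives an at least 24-fold lower number from compound 2 to compound 4 (1.38 log units; beyond the scatter). Among the compounds shown here, this is the first readable step at this position, and it brings a measurable activity to the 4-hydroxyphenyl series. Its full size stays unknown because compound 2 has only a limit: the limit of > 50000 nM in this assay, at which 2 of the 4 values shown sit.

Still open, going by these compounds, is how methoxy, chloro or an amine at this position would compare with trifluoromethoxy. Also open, on these data alone, is whether the same change would lower the number for compound 1, which carries 3-hydroxyphenyl.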